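This account rests on a few compounds, and the source may have more. Where it says the series, first, only, none or still open, it means among the compounds named here.

Measured so far in a functional assay on MCF7 cells (Homo sapiens) for inhibition, read by MTT assay, with a stated time of 72 h; on this read-out higher numbers stand for weaker inhibition and lower numbers for stronger inhibition:
- compound 1 `CCc1oc([C@H](C)/C=C(\C)[C@H](OC(C)=O)[C@H](C)[C@@H](OC(=O)CC(C)C)[C@@H](C)c2oc([C@@H](C)[C@H](CC)OC(C)=O)c(C)c(=O)c2C)c(C)c(=O)c1C`: 25000 nM
- compound 2 `CCc1oc([C@H](C)/C=C(\C)[C@H](O)[C@H](C)[C@@H](OC(=O)CC(C)C)[C@@H](C)c2oc([C@@H](C)[C@@H](O)CC)c(C)c(=O)c2C)c(C)c(=O)c1C`: > 100000 nM

Compound 2 stands at > 100000 nM, which is a limit of the assay and not a number. This is the sole entry of that kind in the pair: the limit of > 100000 nM in this assay, at which 1 of the 2 values shown sits. For the measured compounds named here, compound 1 gives 25000 nM, the only true number so far.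

Compound 3 `CCc1oc([C@H](C)/C=C(\C)[C@H](OC(C)=O)[C@H](C)[C@@H](OC(=O)CC(C)C)[C@@H](C)c2oc([C@@H](C)[C@@H](O)CC)c(C)c(=O)c2C)c(C)c(=O)c1C` is reached from compound 2 by a single change: acetyl in place of hydrogen on an oxygen on a saturated carbon. In words, this is acetyl in place of hydrogen on an oxygen on a saturated carbon, or hydroxy to acetoxy.

Going by the values given here, no measured step shows what this change does in this assay, so the expectation is loose. It rests on compound 1, which gives 25000 nM and marks the range in which a number can be expected. A moderate move toward stronger inhibition is expected, and the estimated step is an at least 2.0-fold lower number from compound 2 to compound 3 (0.30 log units; that floor lies within the scatter). Another reading at the limit remains possible. For compound 3 the estimate is 50000 nM, with an expected range of 18000 nM to 100000 nM.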

Compound 3, half-maximal inhibitory concentration: 15000 nM
Beside the measured number, compound 3's estimate is 3.3-fold (0.52 log units) above it; the whole stated range lies above it.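

In this assay, for the compounds shown here, hydroxy to acetoxy on an oxygen on a saturated carbon gives an at least 6.6-fold lower number from compound 2 to compound 3 (0.82 log units; beyond the scatter), the first reading of this change at this position and one that lifts the series off the limit. This step is only a floor, not a full size, because compound 2 stands at a limit of the assay and not at a number: the limit of > 100000 nM in this assay, at which 1 of the 3 values shown sits.

The reverse change at the other oxygen, hydrogen in place of acetyl, reads a 1.7-fold lower number from compound 1 to compound 3 (0.22 log units; within the scatter), so in this assay the second acetoxy gives no separation and a single acetoxy is enough to bring a measured number.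

The compounds shown leave open how far the true size of the first step reaches, and whether acetoxy at the other oxygen alone would give the same reading. They also leave open whether the effect belongs to acetyl in particular or would hold for a longer chain on the ester, such as butyryl, for a methyl ether on the same oxygen, or for an amine in place of the hydroxy.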